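A few compounds are considered here, and "the series" means these few. Any claim that something is new, unique, unknown or untested is made for them only; others in the source may bear on it.

Measured so far in an ADME assay on HepG2 cells (Homo sapiens), read by MTT assay, with a stated time of 72 h, in the presence of a further agent that is not named here; a lower number here means a stronger inhibitor, a higher number a weaker inhibitor:
- Compound 1 `O=C(NCc1ccccc1)Oc1ccc(Cl)cc1C(=O)Nc1ccc(C(F)(F)F)cc1`: 3000 nM
- Compound 2 `O=C(NC1CCCCC1)Oc1ccc(Cl)cc1C(=O)Nc1ccc(Cl)cc1`: 33600 nM

Compound 2 has the higher of the two numbers, making it the weaker inhibitor of the pair, and its gap to compound 1 lies beyond the usual scatter. The two differ in more than one place, and the data do not show which change accounts for that gap.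

Compound 3 `O=C(NC1CCCCC1)Oc1ccc(Cl)cc1C(=O)Nc1ccc(C(F)(F)F)cc1` has trifluoromethyl in place of chloro on an aromatic carbon of compound 2: trifluoromethyl in place of chloro on an aromatic carbon. A moderate drop in this assay, clearing the scatter, is expected; this rests on compound 1, which carries the same trifluoromethyl and gives 3000 nM. The expected change is a 3.1-fold lower number from compound 2 to compound 3 (0.48 log units; beyond the scatter). For compound 3 the estimated value is 11000 nM, with a range of 3500 nM to 33000 nM.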

Compound 3, half-maximal inhibitory concentration: 750 nM
For compound 3 the middle estimate is 15-fold (1.17 log units) above the measured one, outside the stated range (below it).
By their numbers in this assay, from the lowest: compound 3; then compound 1; then compound 2.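

In this assay the change from 4-chlorophenyl to 4-(trifluoromethyl)phenyl, with cyclohexyl kept in place, gives a 45-fold lower number from compound 2 to compound 3 (1.65 log units; beyond the scatter) and so shows the effect of this change alone, which the earlier pair could not. Cyclohexyl in place of benzyl on the amide-type nitrogen gives a 4.0-fold lower number from compound 1 to compound 3 (0.60 log units; beyond the scatter) and so that other place counts too, though less. Nothing measured here explains either step.

The compounds shown leave open how a nitrile or a methoxy group would fare at this position, and whether the trifluoromethyl step would stay as large with benzyl on the nitrogen.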